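The source may report more compounds than this note shows. Statements on the series, on what has been measured and on what is new or still open speak of the compounds shown alone.

Measured in a functional assay on WiDr cells (Homo sapiens) for antiproliferative activity, read by sulforhodamine B assay, with a stated time of 48 h; on this read-out lower numbers stand for stronger inhibition of growth and higher numbers for weaker inhibition of growth:
compound 1 `CC(C)(C)[Si](C)(C)O[C@@H]1CCCO[C@@H]1COCC(=O)O`: > 100000 nM (a limit)
compound 2 `CC(C)(C)[Si](C)(C)O[C@@H]1CCCO[C@@H]1COCC(=O)OCc1ccccc1`: 37000 nM
compound 3 `O=C1COC[C@H]2OCCC[C@H]2O1`: > 100000 nM (a limit)
Not yet measured: compound 4 `CC(C)(C)[Si](C)(C)O[C@@H]1CCCO[C@@H]1COCCCO`

Compound 1 gives > 100000 nM, which is a limit of the assay and not a number. It therefore stands at the limit of > 100000 nM in this assay, at which 2 of the 3 values shown sit.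

The change under consideration is 2-hydroxyethyl in place of carboxy on a saturated chain carbon bound to an oxygen on a saturated carbon. In words, 2-hydroxyethyl stands in place of carboxy on a saturated chain carbon bound to an oxygen on a saturated carbon. The silyl-bearing core of compound 1 is kept.

For the measured compounds named here, only one measured step bears on this change, since it also alters the carboxy group: an at least 2.7-fold lower number from compound 1 to compound 2 (0.43 log units; beyond the scatter). That step is beyond the scatter, but it brings in a benzyl group, which compound 4 does not have. It offers a direction rather than a size for the present change. A modest step towards a lower number is therefore expected in this assay, and a reading that stays at the limit remains quite possible.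

The expected step is an at least 1.6-fold lower number from compound 1 to compound 4 (0.22 log units; that floor lies within the scatter). Compound 4 is estimated at 60000 nM, with an expected range of 20000 nM to 100000 nM.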

Compound 4, concentration for 50% growth inhibition: > 100000 nM
Compound 4: a limit, no number; the forecaster's own chance of this, stated with the estimate: 45%; middle value at least 1.6-fold (0.22 log units) from the limit.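

In this assay compound 4 gives > 100000 nM, which is a limit and not a number. Compound 1 also sits at a limit, so no step can be read between compound 1 and compound 4: the limit of > 100000 nM in this assay, at which 3 of the 4 values shown sit.

The compounds shown leave open whether 2-hydroxyethyl in place of carboxy on this core changes growth inhibition.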